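Fluoro on the benzyl arm of compound 3

A few compounds are considered here, and "the series" means these few. Any claim that something is new, unique, unknown or untested is made for them only; others in the source may bear on it.

Working notes on the series. Compound 1 `Nc1sc2c(c1C(=O)c1cccc3ccccc13)CCC2` and compound 2 `Nc1sc2c(c1C(=O)c1ccc3ccccc3c1)CCCC2` share the same core with differing saturated rings. In an assay on isolated protein with adenosine receptor A3 (Homo sapiens) as the target, tested at 10 uM (a lower number here means less inhibition, a higher number more inhibition at the concentration tested (going by the name of the read-out)), compound 1 gives 0%, and compound 2 gives 0%. Compound 3 `Nc1sc2c(c1C(=O)c1ccc3ccccc3c1)CCN(Cc1ccccc1)C2` gives 22% in this assay, the highest of the three numbers; its gap to compound 1 and its gap to compound 2 both lie beyond the scatter.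

Compound 4 `Nc1sc2c(c1C(=O)c1ccc3ccccc3c1)CCN(Cc1ccccc1F)C2` differs from compound 3 by fluoro in place of hydrogen on an aromatic carbon. Among the compounds with values here, no step between measured compounds of this kind is known, so the size of this change is an expectation only. The step of a number 3 percentage points higher from compound 3 to compound 4 (within the scatter) is expected to be small and within the scatter. Compound 4 is expected to give 25% in this assay, with a range from 5% to 50%.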

Compound 4, a percentage reported as inhibition, at one concentration (the size of the read-out at that concentration, not a potency): 0%
Estimate against measurement, compound 4: 25 percentage points above, outside the stated range (below it).
By their numbers in this assay, from the lowest: compounds 1, 2 and 4 (each within the scatter of the next); then compound 3.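

In this assay, the change from benzyl to 2-fluorobenzyl gives a number 22 percentage points lower from compound 3 to compound 4 (beyond the scatter) at this one position, so the reading of compound 3 is sensitive to a single fluoro ortho to a large group. Within the data shown here, this is the only step on the benzyl arm so far, and it rests on a single pair of compounds. Nothing available bears on the reason for this step.

Open, from the compounds shown here alone, is whether chloro or methoxy in the same place would go the same way as fluoro. Also open, going by these compounds, is whether fluoro elsewhere on this ring would give the same result.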